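Swapping the aryl group on the oxadiazole of compound 1

The source may report more compounds than this note shows. Statements on the series, on what has been measured and on what is new or still open speak of the compounds shown alone.

Measured compounds:
compound 1, `Cc1nc2cc(OC[C@H](O)CN3CCN(Cc4noc(-c5ccc(C(C)C)cc5)n4)CC3)ccc2s1`: 950 nM
compound 2, `Cc1nc2cc(OC[C@H](O)CN3CCN(Cc4nnc(-c5ccc(Cl)cc5)o4)CC3)ccc2s1`: 8500 nM
compound 3, `Cc1nc2cc(OC[C@H](O)CN3CCN(Cc4nnc(-c5ccc(C(F)(F)F)cc5)o4)CC3)ccc2s1`: 4800 nM

In a functional assay on mitochondria from heart for inhibition of peroxisomal acyl-coenzyme A oxidase 1 (Rattus norvegicus) (on this read-out lower numbers stand for stronger inhibition and higher numbers for weaker inhibition), compound 1 gives the lowest of the three numbers, 950 nM. Its nearest neighbour is compound 3 with 4800 nM, a gap beyond the scatter, and compound 2 with 8500 nM lies furthest away. Among the measured compounds shown here, the only single-point step among the measured compounds, a 1.8-fold lower number from compound 2 to compound 3 (0.25 log units; within the scatter), concerns a different change on a different five-membered ring and stays within the scatter.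

Compound 4, `Cc1nc2cc(OC[C@H](O)CN3CCN(Cc4noc(-c5cccc(F)c5)n4)CC3)ccc2s1`, differs from compound 1 by 3-fluorophenyl in place of 4-isopropylphenyl on an aromatic carbon. For the measured compounds named here, no measured pair covers this change, and the step from compound 2 to compound 3 offers little guidance because it alters a small substituent rather than the whole aryl group. What the numbers do show is that compound 1 with its 4-isopropylphenyl sits well apart from compounds 2 and 3, so a change of that group carries a real risk of moving the number upward in this assay. The account therefore expects a moderate loss, a 3.2-fold higher number from compound 1 to compound 4 (0.50 log units; beyond the scatter), with compound 4 estimated at 3000 nM, in the range 1000 nM to 9000 nM.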

Compound 4, half-maximal inhibitory concentration: 13400 nM
For compound 4 the middle estimate is 4.5-fold (0.65 log units) below the measured one, and the stated range ends below it.
By their numbers in this assay, from the lowest: compound 1; then compounds 3, 2 and 4 (each within the scatter of the next, the first and the last beyond it).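

With the aromatic carbon of the five-membered ring with 2 nitrogen and 1 oxygen as the point of change, replacing 4-isopropylphenyl with 3-fluorophenyl gives, in this assay, a 14-fold higher number from compound 1 to compound 4 (1.15 log units; beyond the scatter), a large step and the only direct measure of this aryl change among the compounds shown. The other single-place step, a 1.8-fold lower number from compound 2 to compound 3 (0.25 log units; within the scatter), stays within the scatter and concerns a small substituent on a different ring, so it gave no sign that the number could respond so strongly to a change at this aromatic carbon. No measurement shown here explains why the number rises so sharply between these two aryl groups.

The step swaps the isopropyl group for fluorine and alters where the substituent sits on the phenyl ring, so the compounds shown cannot separate the contributions of these two differences. They also leave open how an unsubstituted phenyl, a methoxy group or a longer alkyl chain on the phenyl ring would read in this assay, and whether an amine or a carboxylic acid there would be tolerated.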